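A few compounds are considered here, and "the series" means these few. Any claim that something is new, unique, unknown or untested is made for them only; others in the source may bear on it.

Compound 1 `Cc1ccccc1NC(=O)N[C@H](C)c1ccccc1` and compound 2 `Cc1ccccc1NC(=O)N[C@@H](C)c1ccccc1` are built from the same atoms and bonds and differ only in how one stereocentre on a saturated chain carbon is drawn. In an ADME assay on the whole organism with Oryza sativa as the target, tested at 10 uM (a higher number here means a weaker effect of the compound at the concentration tested, a lower number a stronger effect), compound 1 gives 99%, and compound 2 gives 99%. Among the compounds with values here, the step of no change at the digits printed from compound 1 to compound 2 (within the scatter) shows that redrawing that configuration moves nothing; it is the only measured step, and it rests on (the fact that compounds 1 and 2 differ only in the configuration as drawn). Compound 1 thus stands level with compound 2, both at a value that means a weak effect at the concentration tested.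

Compound 3 `C[C@@H](NC(=O)Nc1ccccc1C(C)(C)C)c1ccccc1` has not yet been measured in this assay. It differs from compound 1 by tert-butyl in place of methyl on an aromatic carbon. Within the data shown here, no measured step exchanges one group for another on that aromatic ring, so the single known step, a change of drawn configuration that left the read-out untouched, offers no guide to the size of this one. With both measured compounds at the weak end, the expectation is that compound 3 stays there as well: the step of a number 2 percentage points lower from compound 1 to compound 3 (within the scatter) is expected to lie within the scatter. The estimate for compound 3 in this assay is 97%, in a range from 85% to 100%.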

Compound 3, a percentage reported as activity, at one concentration (the size of the read-out at that concentration, not a potency): 17%
For compound 3 the middle estimate is 80 percentage points above the measured one; measured number below the stated range.
By their numbers in this assay, from the lowest: compound 3; then compounds 1 and 2 (each within the scatter of the next).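

Exchanging methyl for tert-butyl on this aromatic carbon gives a number 82 percentage points lower from compound 1 to compound 3 (beyond the scatter) in this assay, and a lower number here means a stronger effect at the concentration tested. Within the data shown here, the read-out in this assay can therefore move a long way within this small set, and it responds to the group at this place on the ring, whereas the only earlier step, no change at the digits printed from compound 1 to compound 2 (within the scatter), showed a change of drawn configuration leaving it flat. Nothing known about these compounds accounts for the size of this step.

With only two groups compared at this place, the compounds shown cannot tell whether an ethyl or isopropyl group would give a value between those of methyl and tert-butyl, or how a different kind of group, such as a methoxy group or an amine, would behave there. They also leave open whether configuration still makes no difference once tert-butyl is present, since the tert-butyl compound appears here in only one drawn configuration.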